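Sulfonyl side chain change in the fluorophenyl series

A few compounds are considered here, and "the series" means these few. Any claim that something is new, unique, unknown or untested is made for them only; others in the source may bear on it.

Within the data shown here, in a functional assay on cells (Panel colon (Carcinoma cell lines), Homo sapiens) for inhibition, read by sulforhodamine B assay, with a stated time of 48 h (on this read-out lower numbers stand for stronger inhibition and higher numbers for weaker inhibition), compound 2 `O=S(=O)(NCCCNc1nccc(-c2c(-c3cccc(O)c3)nc3sccn23)n1)c1cccc(F)c1` gives 3020 nM and so holds the lower of the two numbers so far, while compound 1 `CN1CCCN(CCNc2nccc(-c3c(-c4cccc(O)c4)nc4sccn34)n2)S1(=O)=O` gives 8080 nM on the same read-out. Compound 3 `O=S(=O)(NCCNc1nccc(-c2c(-c3cccc(O)c3)nc3sccn23)n1)c1ccc(F)cc1` is still unmeasured, and its change from compound 2 ((4-fluorophenyl)sulfonyl)amino in place of (((3-fluorophenyl)sulfonyl)amino)methyl on a saturated chain carbon, two bonds along the chain from a nitrogen on an aromatic ring puts ((4-fluorophenyl)sulfonyl)amino in place of (((3-fluorophenyl)sulfonyl)amino)methyl on a saturated chain carbon, two bonds along the chain from a nitrogen on an aromatic ring. Among the measured compounds shown here, the only measured step is a 2.7-fold lower number from compound 1 to compound 2 (0.43 log units; beyond the scatter) and it is modest, though beyond the scatter. That step replaced a group with a six-membered non-aromatic ring by one with an aromatic ring, whereas here the six-membered aromatic ring of carbon only stays. For the measured compounds named here, no measured pair separates the loss of the methyl from the move of the fluorine. The expected change in this assay is a 1.2-fold higher number from compound 2 to compound 3 (0.06 log units; within the scatter) and it is expected to stay within the scatter, with no firm direction. Compound 3 is estimated at 3500 nM with 1400 nM to 8500 nM as the expected range.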

Compound 3, half-maximal inhibitory concentration: 5420 nM
The estimate for compound 3 lay 1.5-fold (0.19 log units) below the measured number; the range from low to high includes it.
By their numbers in this assay, from the lowest: compounds 2, 3 and 1 (each within the scatter of the next, the first and the last beyond it).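

The step of a 1.8-fold higher number from compound 2 to compound 3 (0.25 log units; within the scatter) shows that, at this place on a saturated chain carbon, ((4-fluorophenyl)sulfonyl)amino and (((3-fluorophenyl)sulfonyl)amino)methyl cannot be told apart in this assay, even though the change alters both the chain and the fluorine position. The new comparison with the cyclic sulfonyl group, a 1.5-fold lower number from compound 1 to compound 3 (0.17 log units; within the scatter), also lies within the scatter, so a group with a six-membered aromatic ring of carbon only does not separate from that group in every case, and the earlier 2.7-fold lower number from compound 1 to compound 2 (0.43 log units; beyond the scatter) remains the only step beyond the scatter among these three compounds. No supporting measurement is available to explain these results.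

Among these compounds, no pair among the three compounds separates the extra methyl from the move between 3-fluorophenyl and 4-fluorophenyl, so neither change can be read alone. Also open, as far as these compounds go, is how a longer chain, or a carboxylic acid or a dimethylamino group in place of the fluorophenyl ring, would read in this assay at this place.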